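Exchanging One Aryl Group for Another in Full Agonists

The compounds below may be only part of what the source reports. "The series", "measured", "known", "first", "only" and "open" are said of these compounds alone.

Compound 1 `N=C(NCCCc1c[nH]cn1)NCCC(c1ccc(Br)cc1)c1ccccn1` gives 1 in a functional assay on cardiac atrium for agonist activity at histamine H2 receptor (Cavia porcellus); a lower number here means a smaller maximal response, a higher number a larger maximal response.
Compound 2 `N=C(NCCCc1c[nH]cn1)NCCC(c1ccccn1)c1ccccc1F` gives 1 in this assay.
Compound 3 `N=C(NCCCc1c[nH]cn1)NCCC(c1ccccn1)c1cccs1` gives 1 in this assay.

Compound 3 stands level with the other two: the step of no change at the digits printed from compound 1 to compound 3 (within the scatter) and the step of no change at the digits printed from compound 2 to compound 3 (within the scatter) both stay within the scatter, as does no change at the digits printed from compound 1 to compound 2 (within the scatter). Compound 4 `N=C(NCCCc1c[nH]cn1)NCCC(c1ccccn1)c1ccccn1` is the next member, and it differs from compound 3 in one place: pyridin-2-yl in place of thiophen-2-yl on a saturated chain carbon bound to an aromatic carbon and a saturated chain carbon. Among the compounds with values here, every measured step so far has exchanged one aryl group for another at this same chain carbon, and none moved the maximal response beyond the scatter. The step from compound 3 to compound 4 is therefore expected to be small, no change at the digits printed from compound 3 to compound 4 (within the scatter), with no direction favoured. Compound 4 is expected to reach 1 in this assay, estimated between 0.9 and 1.05.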

Compound 4, intrinsic activity: the largest response reached, as a fraction of the reference agonist's: 1
For compound 4 middle estimate and measured number coincide at the digits printed; the measured number falls inside the stated range.
By their numbers in this assay, from the lowest: compounds 1, 2, 3 and 4 (each within the scatter of the next).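

In this assay, pyridin-2-yl in place of thiophen-2-yl gives no change at the digits printed from compound 3 to compound 4 (within the scatter), so this chain carbon can carry two identical pyridin-2-yl groups with the maximal response held. Replacing either substituted phenyl group gives the same picture, with no change at the digits printed from compound 2 to compound 4 (within the scatter) and no change at the digits printed from compound 1 to compound 4 (within the scatter) as well. Nothing available explains why the response stays level across these aryl exchanges. Still open is whether a cyclohexyl group, an amine or a carboxylic acid on this chain carbon would hold the response, since every group shown here is aromatic.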